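Methyl for methoxy on a triazole carbinol: no potency expected

A few compounds are considered here, and "the series" means these few. Any claim that something is new, unique, unknown or untested is made for them only; others in the source may bear on it.

Measured compounds:
compound 1 `COc1ccc(-c2cn(C[C@H]3COC(C)(C)O3)nn2)cc1`: > 100000 nM
compound 2 `COc1ccc(C(O)c2cn(Cc3cccc(OC)c3)nn2)cc1`: > 100000 nM

In a functional assay on B16 cells (Mus musculus) for cytotoxicity, read by MTT assay, with a stated time of 48 h (a higher number here means a weaker inhibitor, a lower number a stronger inhibitor), compound 1 gives > 100000 nM, which is a limit of the assay and not a number. Compound 2 likewise gives only > 100000 nM in this assay, again a limit. Compound 2 therefore stands at the edge of what this assay reports, and both values shown sit at the limit of > 100000 nM in this assay, at which 2 of the 2 values shown sit.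

Compound 3 `COc1cccc(Cn2cc(C(O)c3ccc(C)cc3)nn2)c1` is not yet measured in this assay. It differs from compound 2 by methyl in place of methoxy on an aromatic carbon. Within the data shown here, no measured pair here isolates such a change, so the size of the step is open. Given that compound 2 sits at a limit, the step from compound 2 to compound 3 is expected to be a step that the limit leaves unreadable from compound 2 to compound 3, with no change beyond the scatter most likely. Compound 3 is expected to give about 150000 nM, within 30000 nM to 1000000 nM, most probably reported only as a limit.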

Compound 3, half-maximal inhibitory concentration: > 100000 nM
Compound 3 ended at the assay's limit; the forecaster's own chance of this, stated with the estimate: 85%; the middle value does not contradict the limit.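

In this assay compound 2 and compound 3 both stop at a limit and not at a number, so the change from methoxy to methyl gives no readable step: the limit of > 100000 nM in this assay, at which 3 of the 3 values shown sit. The compounds shown leave open whether 4-methoxyphenyl and 4-methylphenyl differ at all, and what would bring a compound inside that limit.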